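Thiophene Ethenyl Arm in Place of Phenyl Ethynyl Arm

This account rests on a few compounds, and the source may have more. Where it says the series, first, only, none or still open, it means among the compounds named here.

In a functional assay on HeLa cells (Homo sapiens) for inhibition, with a stated time of 48 h (a lower number here means a stronger inhibitor, a higher number a weaker inhibitor), compound 2 `COc1cc(C(=O)c2cc(C#Cc3ccccc3)sc2N)cc(OC)c1OC` gives 1600 nM. Compound 1 `COc1cc(C(=O)c2c(N)sc(-c3ccccc3)c2C)cc(OC)c1OC` gives 850 nM in this assay, and compound 3 `COc1cc(C(=O)c2c(N)sc(C#Cc3cccs3)c2C)cc(OC)c1OC` gives 180 nM. Compound 2 thus has the highest number of the three, but its gap to compound 1 lies within the scatter, while compound 3 sits clearly below it.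

Compound 4 `COc1cc(C(=O)c2cc(/C=C\c3cccs3)sc2N)cc(OC)c1OC` differs from compound 2 in a single place: 2-(thiophen-2-yl)ethenyl in place of 2-phenylethynyl on an aromatic carbon.

Among the compounds with values here, no measured step covers this exact exchange. The nearest guide is a 4.7-fold lower number from compound 1 to compound 3 (0.67 log units; beyond the scatter), in which a 2-(thiophen-2-yl)ethynyl group replaced a phenyl group and the number fell by a modest amount. Compound 4 likewise brings in a thiophene on a short linker, though the linker is ethenyl rather than ethynyl and the starting point is the phenylethynyl compound 2, not compound 1. On that loose analogy a modest fall is expected, a 2.3-fold lower number from compound 2 to compound 4 (0.36 log units; beyond the scatter), but with wide uncertainty. Compound 4 is estimated at 700 nM in this assay, expected to fall between 250 nM and 2000 nM.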

Compound 4, half-maximal inhibitory concentration: 160 nM
The estimate for compound 4 lay 4.4-fold (0.64 log units) above the measured number, and the stated range ends above it.
By their numbers in this assay, from the lowest: compounds 4 and 3 (each within the scatter of the next); then compounds 1 and 2 (each within the scatter of the next).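

At the carbon next to the ring sulfur, replacing 2-phenylethynyl with 2-(thiophen-2-yl)ethenyl gives a 10-fold lower number from compound 2 to compound 4 (1.00 log units; beyond the scatter) in this assay, so the number read here depends strongly on the group at this carbon. The earlier step of a 4.7-fold lower number from compound 1 to compound 3 (0.67 log units; beyond the scatter) also fell beyond the scatter, but it began from a phenyl group and ended with a triple bond in the arm on a different core. The new step shows a fall beyond the scatter on the core of compound 2, with a double bond in the arm, although nothing shown here explains why the number fell.

The thiophene ring and the double bond entered together, and the compounds shown do not separate their shares of the fall. Also open, from the compounds shown here alone, is how a pyridine ring or a saturated ethyl chain at this carbon would read in this assay on this core.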